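Swapping the benzoyl substituent on a nitrophenylhydrazone core

A few compounds are considered here, and "the series" means these few. Any claim that something is new, unique, unknown or untested is made for them only; others in the source may bear on it.

Measured compounds:
- compound 1 `CC(/C=N/Nc1ccc([N+](=O)[O-])cc1)=N\NC(=O)c1ccccc1O`: 29500 nM
- compound 2 `CC(/C=N/Nc1ccc([N+](=O)[O-])cc1)=N\NC(=O)c1ccccc1N`: 29800 nM
- compound 3 `CC(/C=N/Nc1ccc([N+](=O)[O-])cc1)=N\NC(=O)c1ccccc1I`: 40000 nM

All three compounds were tested in an ADME assay on J774 cells (Mus musculus, strain BALB/c) for cytotoxicity, read by resazurin assay, with a stated time of 72 h; on this read-out higher numbers stand for lower toxicity in this test and lower numbers for higher toxicity in this test. Compound 1 gives the lowest of the three numbers, yet it is not set apart from the others: the step of a 1.0-fold higher number from compound 1 to compound 2 (0.00 log units; within the scatter) and the step of a 1.4-fold higher number from compound 1 to compound 3 (0.13 log units; within the scatter) are both within the scatter, as is a 1.3-fold higher number from compound 2 to compound 3 (0.13 log units; within the scatter). The three compounds thus behave alike in this assay.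

Compound 4 `CC(/C=N/Nc1ccc([N+](=O)[O-])cc1)=N\NC(=O)c1ccc(N(C)C)cc1` is not yet measured. It differs from compound 1 in one place: 4-(dimethylamino)phenyl in place of 2-hydroxyphenyl on a carbonyl carbon. Among the measured compounds shown here, none of the measured steps touches this part of the structure in the same way; they only exchange one small substituent for another on the same ring, and each of them stayed within the scatter. There is therefore no sign in the data that a change on this ring moves the number, and for compound 4 no step beyond the scatter is expected, that is a 1.1-fold higher number from compound 1 to compound 4 (0.05 log units; within the scatter). The estimate for compound 4 is 33000 nM, with a range from 15000 nM to 70000 nM.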

Compound 4, half-maximal cytotoxic concentration: > 100000 nM
Compound 4 was reported as a limit (the forecaster's own chance of this, stated with the estimate: 10%); middle value at least 3.0-fold (0.48 log units) away from the limit.
By their numbers in this assay, from the lowest: compounds 1, 2 and 3 (each within the scatter of the next). At a limit, above all of these: compound 4.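

In this assay, compound 4 is reported only as a limit, not as a number: the limit of > 100000 nM in this assay, at which 1 of the 4 values shown sits. The exchanges among 2-hydroxyphenyl, 2-aminophenyl and 2-iodophenyl all stayed within the scatter, but the change to 4-(dimethylamino)phenyl on the carbonyl carbon gives an at least 3.3-fold higher number from compound 1 to compound 4 (0.53 log units; beyond the scatter), an at least 3.3-fold higher number from compound 2 to compound 4 (0.52 log units; beyond the scatter) and an at least 2.5-fold higher number from compound 3 to compound 4 (0.39 log units; beyond the scatter). The group on this carbonyl carbon can therefore shift the read-out towards lower toxicity in this test, which the first three compounds gave no sign of.

Compound 4 differs from the others both in its substituent and in where that substituent sits on the ring, and the compounds shown do not separate these two changes. From the compounds shown here alone, it also remains open how a primary amine or a carboxylic acid would read in place of the dimethylamino group.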